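This account rests on a few compounds, and the source may have more. Where it says the series, first, only, none or still open, it means among the compounds named here.

Measured compounds:
- compound 1, `O=C(CSc1nc(Nc2ccccc2)c2ccccc2n1)Nc1cccc(F)c1`, in a functional assay on NCI-H1975 cells (Homo sapiens) for inhibition, read by MTT assay, with a stated time of 72 h (on this read-out higher numbers stand for weaker inhibition and lower numbers for stronger inhibition), compound 1 gives 6790 nM.
- compound 2, `C=CC(=O)Nc1cccc(NC(=O)CSc2nc(Nc3cccc(Cl)c3)c3ccccc3n2)c1`, in this assay compound 2 gives 9460 nM.

The two numbers lie within the usual scatter of repeated measurements of each other, so compound 2 does not stand apart from compound 1 on this read-out; both sit in the weakly inhibiting range, and no difference between them can be claimed.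

Compound 3, `C=CC(=O)Nc1cccc(NC(=O)CSc2nc(Nc3ccc(Cl)cc3Cl)c3ccccc3n2)c1`, has not yet been measured. It differs from compound 2 in one place: 2,4-dichlorophenyl in place of 3-chlorophenyl on a nitrogen on an aromatic ring. The rest of the shared core, including the acrylamide-bearing side and the thioether linker, is unchanged. For the measured compounds named here, no measured pair shows what such a change does here, so the expectation rests only on the two numbers above. The step from compound 2 to compound 3 is expected to be small, a 1.1-fold lower number from compound 2 to compound 3 (0.02 log units; within the scatter), with no clear direction beyond the scatter. Compound 3 is therefore estimated at 9000 nM in this assay, within a range from 3500 nM to 25000 nM.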

Compound 3, half-maximal inhibitory concentration: 5990 nM
Compound 3: middle estimate off by 1.5-fold (0.18 log units), on the high side; the range from low to high includes it.
By their numbers in this assay, from the lowest: compounds 3, 1 and 2 (each within the scatter of the next).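

In this assay, for the compounds shown here, putting 2,4-dichlorophenyl in place of 3-chlorophenyl on the nitrogen gives a 1.6-fold lower number from compound 2 to compound 3 (0.20 log units; within the scatter) and offers the first direct reading of a change at this position. This step lies within the usual scatter of repeated measurements, so compound 2 and compound 3 cannot be told apart, and the added chlorine brings no change that can be claimed on this read-out. No supporting measurement bears on this result, so the data offer no explanation for it.

The compounds shown leave open whether any group on this phenyl ring can shift the number beyond the scatter, for example a methoxy group, an amine or a carboxylic acid in place of chlorine. Compound 1 differs from compound 2 and compound 3 in more than one place, so the separate contributions of the acrylamide-bearing side and of the chlorine substituents cannot be read from these compounds.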